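Amide Ring Swap with an Open Question

The compounds below may be only part of what the source reports. "The series", "measured", "known", "first", "only" and "open" are said of these compounds alone.

Compound 1 `COC(=O)c1scc(-c2ccc(NC(=O)c3ccc(C#N)nc3)cc2)c1OC`: "not determined" (no result reported) in a functional assay on HeLa cells (Homo sapiens) for antiproliferative activity, read by MTT assay, with a stated time of 24 h; a lower number here means a stronger inhibitor, a higher number a weaker inhibitor
Compound 2 `COC(=O)c1scc(-c2ccc(NC(=O)c3cccc(C(F)(F)F)c3)cc2)c1OC`: 19300 nM

Two measured compounds share one core and differ only in the ring attached to the amide carbonyl. For compound 1 the entry in this assay reads "not determined" (no result reported), so it stands nowhere on the scale. Compound 2 gives 19300 nM in this assay, a weak inhibitor. Compound 3 `COC(=O)c1scc(-c2ccc(NC(=O)c3ccc(F)c(Cl)n3)cc2)c1OC` is the unmeasured member, obtained from compound 1 by 6-chloro-5-fluoropyridin-2-yl in place of 6-cyanopyridin-3-yl on a carbonyl carbon. Within the data shown here, no measured pair spans this change, so its size in this assay cannot be read from the data. Given that the only measured relative, compound 2, sits at 19300 nM, compound 3 is expected to remain in the same weak region, with no step beyond the scatter foreseen in either direction. Compound 3 is estimated at 20000 nM in this assay, with a range from 5000 nM to 80000 nM.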

Compound 3, half-maximal inhibitory concentration: 16200 nM
The estimate for compound 3 lay 1.2-fold (0.09 log units) above the measured number, within the range that was stated.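

In this assay, among these compounds, 6-chloro-5-fluoropyridin-2-yl in place of 3-(trifluoromethyl)phenyl on a carbonyl carbon amounts to a 1.2-fold lower number from compound 2 to compound 3 (0.08 log units; within the scatter), so the first readable step at this position lies within the scatter. Two quite different rings at this place, one a substituted phenyl and the other a substituted pyridine, thus leave the number in the same weak region, while steps involving compound 1 cannot be read, as it has no number. Nothing shown gives a reason why these two groups read alike.

On these data alone, whether a piperidine or a carboxylic acid on this carbonyl carbon would take the number out of the weak region remains open. As far as these compounds go, what the 6-cyanopyridin-3-yl group itself contributes also remains unknown.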